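The source may hold more compounds than are shown below. What is called first, only, known or untested is meant among the compounds shown, and "the series" means these compounds.

Three compounds measured in an ADME assay on HEK293 cells (Homo sapiens) for cytotoxicity, read by reporter gene assay and resazurin assay, with a stated time of 48 h (a lower number here means that less compound is tolerated, a higher number that more compound is tolerated), set the scene. Compound 1 `O=C(Nc1ccc(Sc2nc3ccccc3s2)c(Cl)c1)c1ccccc1O` gives 64000 nM, compound 2 `O=C(Nc1ccc(Sc2nc3ccccc3s2)cc1)c1ccccc1O` gives 74000 nM, and compound 3 `O=C(Nc1cccc(Cl)c1)c1cccc(Br)c1` gives 51000 nM. Compound 1 stands second highest of these three numbers, with compound 2 nearest and compound 3 furthest, yet all three lie within the scatter of one another, so none can be called more or less tolerated than the rest. Within the data shown here, the one step between neighbours, a 1.2-fold higher number from compound 1 to compound 2 (0.06 log units; within the scatter), swaps hydrogen in place of chloro on an aromatic carbon and changes little.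

Compound 4 `COc1c(Br)cc(Br)cc1C(=O)Nc1ccc(Sc2nc3ccccc3s2)c(Cl)c1` differs from compound 1 on a carbonyl carbon: a group of 10 heavy atoms (7 carbon, 1 oxygen, 2 bromine; one six-membered aromatic ring of carbon only) in place of a group of 7 heavy atoms (6 carbon, 1 oxygen; one six-membered aromatic ring of carbon only), on a carbonyl carbon. Among the measured compounds shown here, no measured step touches that carbonyl side of the shared core, so nothing here speaks directly to this change; the only guide is that every difference seen so far stayed within the scatter. Compound 4 is therefore expected to show a step of a 1.3-fold lower number from compound 1 to compound 4 (0.11 log units; within the scatter), no larger than the scatter, giving an estimated 50000 nM in this assay, within a range from 20000 nM to 100000 nM.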

Compound 4, half-maximal cytotoxic concentration: > 100000 nM
Compound 4 ended at the assay's limit; the forecaster's own chance of this, stated with the estimate: 10%; at least 2.0-fold (0.30 log units) between middle value and limit.
By their numbers in this assay, from the lowest: compounds 3, 1 and 2 (each within the scatter of the next). At a limit, above all of these: compound 4.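

Among these compounds, this is the first look at the carbonyl side of the shared core, and an at least 1.5-fold higher number from compound 1 to compound 4 (0.19 log units; that floor lies within the scatter). Because compound 4 sits at the top of what this assay can report, it gives a limit rather than a number: the limit of > 100000 nM in this assay, at which 1 of the 4 values shown sits. So putting the group of 10 heavy atoms, with its 2 bromine and 0 hydrogen-bond donors, in place of 2-hydroxyphenyl on this carbonyl carbon gives no sign of less compound being tolerated, but the true size of the step stays unknown and its floor cannot be told apart from no change.

The compounds shown do not separate the bromine atoms from the loss of the hydrogen-bond donor, since both arrive in the same step. On these data alone, how an amine or a carboxylic acid would fare in this place also remains open.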